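Trading an Isopropyl for a Methyl on a Shared Core

This account rests on a few compounds, and the source may have more. Where it says the series, first, only, none or still open, it means among the compounds named here.

Of the compounds shown here, two have been measured so far in a functional assay with Nucleic Acid as the target, tested at 10 uM; a lower number here means a weaker effect, a higher number a stronger effect of the compound at the concentration tested. Compound 1 `CCCC1=C(N2CC2)C(=O)C(CCC)=C(N2CC2)C1=O` carries two propyl groups on the shared core, and in this assay compound 1 gives 16.4%. Compound 2 `CC(C)C1=C(N2CC2)C(=O)C(C(C)C)=C(N2CC2)C1=O` carries two isopropyl groups instead, and in this assay compound 2 gives 0%. That puts compound 2 at the lower of the two numbers, and its gap to compound 1 lies beyond the usual scatter of this kind of measurement, so the pair of branched groups goes with a weaker effect than the pair of straight chains here.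

Compound 3 `CC1=C(N2CC2)C(=O)C(C(C)C)=C(N2CC2)C1=O` has not yet been measured. It keeps one isopropyl group and both aziridin-1-yl groups but changes one place: methyl in place of isopropyl on a double-bonded ring carbon. Going by the values given here, no measured pair shows this particular change, so its size can only be guessed. Because compound 2 sits at 0%, there is no room to fall, and the smaller group may edge the number upward. The expected step is a number 8 percentage points higher from compound 2 to compound 3 (within the scatter), small and quite possibly within the scatter. Compound 3 is therefore estimated at 8%, within a range from 0% to 25%.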

Compound 3, a percentage reported as activity, at one concentration (the size of the read-out at that concentration, not a potency): 28.1%
For compound 3 the middle estimate is 20.1 percentage points below the measured one; measured number outside the range, above it.
By their numbers in this assay, from the lowest: compound 2; then compound 1; then compound 3.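

The change from isopropyl to methyl on a double-bonded ring carbon, with the other isopropyl and both aziridin-1-yl groups left in place, produces a number 28.1 percentage points higher from compound 2 to compound 3 (beyond the scatter) in this assay. Going by these compounds alone, this is the first pair in the set that differs in only one place, so the shift can be tied to this single position rather than to two groups changed together. It shows that the group at this position matters to the read-out, and that replacing isopropyl with methyl here goes with a stronger effect, but no measurement available here accounts for that shift.

A single step cannot show whether the read-out follows the size of the chain at this position, and placing a hydrogen, an ethyl group or a longer chain such as butyl there would test this, while an amine or a methoxy group would show whether a group containing something other than carbon and hydrogen can take its place. On these data alone, it also remains open whether exchanging the remaining isopropyl group for methyl would produce a step of similar size or whether the two positions behave differently.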